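The source may report more compounds than this note shows. Statements on the series, on what has been measured and on what is new or still open speak of the compounds shown alone.

Going by the values given here, in an in vitro ADME assay on microsomes from liver (Homo sapiens) for pharmacokinetics (a higher number here means faster removal of the compound, a lower number slower removal), compound 2 `Cc1ccc(S(=O)(=O)N2C=CNC(=O)[C@H]2CC(=O)N[C@@H]2CCCc3ccccc32)cc1` gives 514 mL.min-1.g-1, the only exact number so far. Compound 1 `Cc1ccc(S(=O)(=O)N2C=CNC(=O)[C@H]2CC(=O)N[C@@H]2CCCc3cc(CN4CCCCC4)ccc32)cc1` gives only a limit of the assay, < 50 mL.min-1.g-1. The next change leads to compound 3 `Cc1ccc(S(=O)(=O)N2C=CNC(=O)[C@H]2CC(=O)N[C@@H]2CCC(O)c3ccccc32)cc1`: hydroxy in place of hydrogen on a saturated ring carbon. Among the compounds with values here, the one measured step, an at least 10-fold higher number from compound 1 to compound 2 (1.01 log units; beyond the scatter), is large but lies on an aromatic carbon, so it bears only loosely on this change. A modest fall in this assay is expected, with an estimated step of a 2.1-fold lower number from compound 2 to compound 3 (0.31 log units; beyond the scatter). For compound 3 the expected value is 250 mL.min-1.g-1, with an estimated range of 90 mL.min-1.g-1 to 550 mL.min-1.g-1.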

Compound 3, intrinsic clearance in microsomes: < 50 mL.min-1.g-1
Compound 3 ended at the assay's limit (the forecaster's own chance of this, stated with the estimate: 7%); middle value at least 5.0-fold (0.69 log units) from the limit.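

In this assay, a single hydroxy on this saturated ring carbon, three ring bonds from the ring atom that bears the large group, produces an at least 10-fold lower number from compound 2 to compound 3 (1.01 log units; beyond the scatter); the earlier step showed a change of this size only on an aromatic carbon. The value of compound 3, < 50 mL.min-1.g-1, is a limit of the assay and not a number. The full size of this step therefore stays unresolved: the limit of < 50 mL.min-1.g-1 in this assay, at which 2 of the 3 values shown sit.

From the compounds shown here alone, whether a methoxy, a fluorine or an amine on this carbon would give a step of similar size remains open. Equally open, going by these compounds, is whether a hydroxy on another saturated ring carbon would do the same.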